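From Methoxy to Ethoxy: Compound 1 to Compound 3

The source may hold more compounds than are shown below. What is called first, only, known or untested is meant among the compounds shown, and "the series" means these compounds.

Compound 1 `COc1ccc(S(=O)(=O)N2CCN(c3ccccc3F)CC2)cc1S(=O)(=O)N1CCN(c2ccccc2F)CC1`: 77.8%
Compound 2 `COc1ccc(S(=O)(=O)N2CCN(c3cccc(C)c3)CC2)cc1S(=O)(=O)N1CCN(c2cccc(C)c2)CC1`: 85.2%

In an ADME assay on L929 cells (Mus musculus) for cytotoxicity, read by CCK-8 assay, with a stated time of 48 h, tested at 10 uM (a lower number here means a stronger effect, a higher number a weaker effect of the compound at the concentration tested), compound 1 gives 77.8%, and compound 2 gives 85.2%; the two values lie within the scatter of each other, so neither stands apart. Compound 3 `CCOc1ccc(S(=O)(=O)N2CCN(c3ccccc3F)CC2)cc1S(=O)(=O)N1CCN(c2ccccc2F)CC1` is not yet measured. It differs from compound 1 by methyl in place of hydrogen on a saturated chain carbon bound to an oxygen on an aromatic ring. Going by the values given here, with no measured pair of this kind to lean on, the step is expected to stay within the scatter, in no particular direction: compound 3 is expected at 78%, between 63% and 93%, a step of a number 0.2 percentage points higher from compound 1 to compound 3 (within the scatter).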

Compound 3, a percentage reported as activity, at one concentration (the size of the read-out at that concentration, not a potency): 70.4%
Estimate against measurement, compound 3: 7.6 percentage points above; low and high end bracket the measured number.
By their numbers in this assay, from the lowest: compounds 3, 1 and 2 (each within the scatter of the next, the first and the last beyond it).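

Going by these compounds alone, this is the first measured step at the saturated chain carbon bound to an oxygen on an aromatic ring. Measured in this assay the change from methoxy to ethoxy gives a number 7.4 percentage points lower from compound 1 to compound 3 (within the scatter) and so does not set the two compounds apart. Nothing available explains this step.

The compounds shown leave open whether a longer chain, such as propoxy, or an amine at this place would step beyond the scatter. They also leave open whether ethoxy would give a similar step on the core of compound 2.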